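Benzofuran for Thiophene on Two Ribosylated Cores

This account rests on a few compounds, and the source may have more. Where it says the series, first, only, none or still open, it means among the compounds named here.

The set comprises four nucleoside-like compounds built on two related cores. Compound 1 `Cc1nc(N)c2c(-c3cccs3)cn([C@@H]3O[C@H](CO)[C@@H](O)[C@H]3O)c2n1` carries a thiophen-2-yl group, and compound 2 `Cc1nc(N)c2c(-c3cc4ccccc4o3)cn([C@@H]3O[C@H](CO)[C@@H](O)[C@H]3O)c2n1` carries a 1-benzofuran-2-yl group in its place. Compound 3 `CN(C)c1ncnc2c1c(-c1cccs1)cn2[C@@H]1O[C@H](CO)[C@@H](O)[C@H]1O` shares the thiophen-2-yl group with compound 1 but rests on a different core; how the two cores differ is not broken down here. Compound 4 `CN(C)c1ncnc2c1c(-c1cc3ccccc3o1)cn2[C@@H]1O[C@H](CO)[C@@H](O)[C@H]1O` is the unmeasured partner of compound 3.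

All three measured compounds were run in an ADME assay on MRC5 cells (Homo sapiens), read by MTT assay, with a stated time of 72 h; on this read-out lower numbers stand for stronger inhibition and higher numbers for weaker inhibition. Compound 1 reached only the limit of the assay, > 100000 nM. Compound 2 gave a number, 91800 nM. Compound 3 likewise sat at the limit, > 100000 nM.

The change 1-benzofuran-2-yl in place of thiophen-2-yl on an aromatic carbon produced an at least 1.0-fold lower number from compound 1 to compound 2 (0.03 log units; that floor lies within the scatter), a movement that cannot be distinguished from no movement at all. The change from compound 3 to compound 4 is 1-benzofuran-2-yl in place of thiophen-2-yl on an aromatic carbon, the same change at the same place on the other core. Among the measured compounds shown here, since the only measured instance of this change ran into (the limit of > 100000 nM in this assay, at which 2 of the 3 values shown sit), the step from compound 3 to compound 4 is expected to be a number no higher from compound 3 to compound 4 (the limit leaves the size open). On that basis compound 4 is estimated to give 100000 nM in this assay, with a range from 40000 nM to 250000 nM.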

Compound 4, half-maximal inhibitory concentration: > 100000 nM
Compound 4 ended at the assay's limit; the forecaster's own chance of this, stated with the estimate: 60%; the middle value sits exactly at the limit.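

No step can be read from compound 3 to compound 4, because each of the two stands at a limit of the assay and not at a number: the limit of > 100000 nM in this assay, at which 3 of the 4 values shown sit.

The compounds shown leave open whether 1-benzofuran-2-yl in place of thiophen-2-yl on an aromatic carbon changes the read-out at all on the core of compound 3.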